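The compounds below may be only part of what the source reports. "The series", "measured", "known", "first", "only" and "open" are said of these compounds alone.

Measured so far in a functional assay on SK-BR-3 cells (Homo sapiens) for cytotoxicity, read by CellTiter-Glo, with a stated time of 72 h; on this read-out higher numbers stand for weaker inhibition and lower numbers for stronger inhibition:
- compound 1 `CO/N=C1/[C@@H](OC)C[C@H](C)CC2=C(NCCN(C)C)C(=O)C=C(NC(=O)/C(C)=C/C=C\[C@H](OC)[C@@H](OC(N)=O)/C(C)=C/[C@@H]1C)C2=O` gives 550 nM
- compound 2 `CO[C@H]1C[C@H](C)CC2=C(NCCN(C)C)C(=O)C=C(NC(=O)/C(C)=C/C=C\[C@H](OC)[C@@H](OC(N)=O)/C(C)=C/[C@H](C)/C1=N\O)C2=O` gives 95 nM

Compound 2 holds the lower of these two numbers. Compound 3 `CO[C@H]1C[C@H](C)CC2=C(NCCN(C)C)C(=O)C=C(NC(=O)/C(C)=C/C=C\[C@H](OC)[C@@H](OC(N)=O)/C(C)=C/[C@H](C)/C1=N\OCc1ccccc1)C2=O` differs from it by benzyl in place of hydrogen on an oxygen in a change of hydroxy to benzyloxy. Within the data shown here, the one measured step bearing on this is a 5.8-fold lower number from compound 1 to compound 2 (0.76 log units; beyond the scatter) with hydrogen in place of methyl on an oxygen, so a group on that oxygen in compound 3 is expected to give a higher number, although benzyl itself is unmeasured. The expected step is a 3.2-fold higher number from compound 2 to compound 3 (0.50 log units; beyond the scatter) in that direction, modest in size. Compound 3 is estimated at 300 nM within 90 nM to 1000 nM as the expected range.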

Compound 3, half-maximal inhibitory concentration: 480 nM
Beside the measured number, compound 3's estimate is 1.6-fold (0.20 log units) below it; measured number inside the range.
By their numbers in this assay, from the lowest: compound 2; then compounds 3 and 1 (each within the scatter of the next).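

In this assay, benzyl on the oxygen bound to the double-bonded nitrogen also gives a higher number than the free hydroxy, with a 5.1-fold higher number from compound 2 to compound 3 (0.70 log units; beyond the scatter). Methyl and benzyl on this oxygen cannot be told apart, with a 1.1-fold lower number from compound 1 to compound 3 (0.06 log units; within the scatter), so among these three compounds only the free hydroxy of compound 2 stands apart, at the low end. No evidence at hand gives an explanation for this.

Still open, from the compounds shown here alone, is whether any group on this oxygen can match the hydroxy, for example an ethyl chain ending in an amine or a carboxylic acid.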